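From isobutyl to isobutylsulfanyl on a shared core

This account rests on a few compounds, and the source may have more. Where it says the series, first, only, none or still open, it means among the compounds named here.

Of the compounds shown here, two with the same core have been measured so far in a functional assay on aorta (VSMC cells, Rattus norvegicus); a higher number here means that more compound is needed for the effect, a lower number that less compound is needed. Compound 1 `CC(C)OC1=NS(=O)(=O)c2cc(Cl)ccc2N1` gives 22700 nM, while compound 2 `CC(C)CC1=NS(=O)(=O)c2cc(Cl)ccc2N1` gives 5800 nM. This is the lower of the two numbers, so less of compound 2 is needed for the effect.

Compound 3 `CC(C)CSC1=NS(=O)(=O)c2cc(Cl)ccc2N1` carries isobutylsulfanyl in place of isobutyl on a carbon with a double bond to nitrogen. For the measured compounds named here, no measured step makes this exact swap, so the only guide is indirect. That guide is a 3.9-fold lower number from compound 1 to compound 2 (0.59 log units; beyond the scatter), a modest change in which isobutyl replaced isopropoxy at the same place. Isobutylsulfanyl resembles isopropoxy in not being joined to the core through carbon, and compound 1 with isopropoxy stands at 22700 nM. A step of no more than modest size is therefore expected, leaning towards a higher number in this assay. The estimated change is a 1.6-fold higher number from compound 2 to compound 3 (0.19 log units; within the scatter), and one earlier step supports it only weakly. For compound 3, the expected value is 9000 nM, with an estimated range from 3000 nM to 25000 nM.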

Compound 3, half-maximal effective concentration: 6200 nM
Compound 3: middle estimate off by 1.5-fold (0.16 log units), on the high side, within the range that was stated.
By their numbers in this assay, from the lowest: compounds 2 and 3 (each within the scatter of the next); then compound 1.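

In this assay, this position tolerates the swap from isobutyl to isobutylsulfanyl with no readable change (a step of a 1.1-fold higher number from compound 2 to compound 3 (0.03 log units; within the scatter)), so adding a sulfur to the chain at this place leaves the number within the scatter. The other new comparison (a step of a 3.7-fold lower number from compound 1 to compound 3 (0.56 log units; beyond the scatter)) shows that a group not joined to the core through carbon can still sit well clear of compound 1, so being joined through something other than carbon does not by itself go with the high number of the isopropoxy compound. No measured evidence here explains either result.

Isopropoxy and isobutylsulfanyl differ in both the joining atom and the chain, so these compounds cannot separate the two features; an isobutoxy group at the same place would pair the oxygen link with the isobutyl chain. Also open, from the compounds shown here alone, is how far this tolerance extends, for example to an isobutylamino group or a longer chain such as hexyl.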